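Butyl for bromophenyl on the triazole of compound 1

The source may hold more compounds than are shown below. What is called first, only, known or untested is meant among the compounds shown, and "the series" means these compounds.

compound 1 `O=C1O[C@H]([C@@H](O)Cn2cc(-c3ccc(Br)cc3)nn2)C(OCc2ccccc2)=C1OCc1ccccc1` — 3760 nM
compound 2 `CCCCCc1ccc(-c2cn(C/C=C3\OC(=O)C(OCc4ccccc4)=C3OCc3ccccc3)nn2)cc1` — > 100000 nM

Two compounds of this series have been run in a functional assay on SW-620 cells (Homo sapiens) for antiproliferative activity, read by MTT assay, with a stated time of 72 h; on this read-out higher numbers stand for weaker inhibition and lower numbers for stronger inhibition. Among the measured compounds shown here, compound 1 gives 3760 nM, the only plain number in this set. For the measured compounds named here, compound 2 comes back only as the limit of > 100000 nM in this assay, at which 1 of the 2 values shown sits, so its result is a limit of the assay and not a number; as the two compounds differ in more than one place, no step can be drawn between them.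

Compound 3 `CCCCc1cn(C[C@H](O)[C@H]2OC(=O)C(OCc3ccccc3)=C2OCc2ccccc2)nn1` is not yet measured. It differs from compound 1 in one place: butyl in place of 4-bromophenyl on an aromatic carbon. The shared core and the hydroxyl-bearing linker are kept.

Going by the values given here, no measured pair isolates this change, so the expected step rests on compound 1 alone. A modest weakening is expected, a step of a 2.1-fold higher number from compound 1 to compound 3 (0.33 log units; beyond the scatter) from compound 1 to compound 3, not far beyond the usual scatter. Compound 3 is therefore estimated at 8000 nM in this assay, within a range from 3000 nM to 25000 nM.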

Compound 3, half-maximal inhibitory concentration: 47500 nM
For compound 3 the middle estimate is 5.9-fold (0.77 log units) below the measured one; measured number outside the range, above it.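

In this assay, among the compounds shown here, the group on this carbon of the triazole proves to matter: butyl in place of 4-bromophenyl gives a 13-fold higher number from compound 1 to compound 3 (1.10 log units; beyond the scatter), and this is the first comparison that isolates a single place. With the shared core and the hydroxyl-bearing linker kept, 4-bromophenyl is the better of these two groups at this position on this read-out, and the open-chain butyl does not hold the level of compound 1. The data shown give no cause for the size of this step.

The change removes the aromatic ring and the bromine together, leaving their separate shares of the step unresolved; a plain phenyl or a 4-chlorophenyl at this carbon would begin to separate them. Also open, going by these compounds, is whether a ring is needed at all or a longer chain such as octyl could match 4-bromophenyl, and whether a polar group such as an amine or a carboxylic acid is accepted at this position.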